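A few compounds are considered here, and "the series" means these few. Any claim that something is new, unique, unknown or untested is made for them only; others in the source may bear on it.

Measured in a functional assay on HEL cells (Homo sapiens); a lower number here means that less compound is tolerated, a higher number that more compound is tolerated:
Compound 1 `CCCCCCCCc1cc2cn(COCCO)c(O)nc-2n1`: 65000 nM
Compound 2 `CCCCCCc1cc2cn(COCCO)c(=O)nc2o1`: > 200000 nM, a limit of the assay

Among the measured compounds shown here, compound 1 holds the only actual number in this small set, so there is no series of values in which to rank it. The other result, from compound 2, is the limit of > 200000 nM in this assay, at which 1 of the 2 values shown sits.

Compound 3 `CCCCCCc1cc2cn(COCCO)c(O)nc-2n1` has not yet been measured. It differs from compound 1 in one place: hydrogen in place of ethyl on a saturated chain carbon, six bonds along the chain from an aromatic carbon. This is hydrogen in place of ethyl on a saturated chain carbon, six bonds along the chain from an aromatic carbon, so the chain ends sooner.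

For the measured compounds named here, no measured pair shows what such a change does in this assay, so what follows is a judgement. A moderate rise is expected, with more compound tolerated, and it should lie somewhat beyond the usual scatter. That direction rests only loosely on compound 2, whose result of > 200000 nM is a limit. The estimated step is a 2.0-fold higher number from compound 1 to compound 3 (0.30 log units; within the scatter). For compound 3 the expected value is 130000 nM, with an estimated range from 60000 nM to 200000 nM.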

Compound 3, half-maximal cytotoxic concentration: > 200000 nM
Compound 3 gave a limit, no number; the forecaster's own chance of this, stated with the estimate: 35%; middle value at least 1.5-fold (0.18 log units) from the limit.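

In this assay, hydrogen in place of ethyl on a saturated chain carbon, six bonds along the chain from an aromatic carbon, gives an at least 3.0-fold higher number from compound 1 to compound 3 (0.48 log units; beyond the scatter), a change that lies beyond the usual scatter. Among the compounds shown here, the earlier compounds included no pair differing in one place, so this is the first direct reading at this position: with the rest of the structure held the same, the shorter chain allows more compound to be tolerated. Compound 3 gave a limit and not a number, so the step has a lower bound but no known size, and the results now gather at that limit: the limit of > 200000 nM in this assay, at which 2 of the 3 values shown sit.

The compounds shown leave open how the number changes with chain length, including whether a chain of intermediate length would give a value that can be read, or a longer chain than that of compound 1 would give a lower number still. They also leave open whether a hydroxyl group or a carboxylic acid at the chain end would change the result in this assay.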